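Replacing Diethylamino with Isopropylsulfanyl on a Shared Core

This account rests on a few compounds, and the source may have more. Where it says the series, first, only, none or still open, it means among the compounds named here.

Going by the values given here, compound 2 `CCN(CC)C(=O)C1=C(C)NC(=O)NC1c1ccsc1` is one of two compounds measured in an assay on membranes from HeLa cells for displacement of a labelled ligand from adenosine receptor A3 (Homo sapiens), read by scintillation counting, with a stated time of 180 min, tested at 1 uM (on this read-out higher numbers stand for more inhibition at the one concentration tested (going by the name of the read-out) and lower numbers for less inhibition), and compound 2 gives 35% there. It stands highest of the two numbers shown; the nearest, compound 1 `CC(=O)C1=C(C)NC(=O)NC1c1ccsc1`, gives 1% in this assay. Among the compounds with values here, the only step between them, a number 34 percentage points higher from compound 1 to compound 2 (beyond the scatter), arises from diethylamino in place of methyl on a carbonyl carbon.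

Compound 3 `CC1=C(C(=O)SC(C)C)C(c2ccsc2)NC(=O)N1` has not yet been measured. It differs from compound 2 in one place: isopropylsulfanyl in place of diethylamino on a carbonyl carbon. The step from compound 1 to compound 2 bears on this change only in part: it shows that the group on this carbonyl carbon moves the read-out by a large amount, but nothing has been measured for isopropylsulfanyl itself. Given that diethylamino leaves again and that a number 34 percentage points higher from compound 1 to compound 2 (beyond the scatter) was large, a downward step in this assay is expected for compound 3, with wide uncertainty. Compound 3 is estimated to give 18%, within a range of 0% to 45%. The expected step is therefore a number 17 percentage points lower from compound 2 to compound 3 (beyond the scatter).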

Compound 3, a percentage reported as inhibition, at one concentration (the size of the read-out at that concentration, not a potency): 1%
Beside the measured number, compound 3's estimate is 17 percentage points above it; low and high end bracket the measured number.
By their numbers in this assay, from the lowest: compounds 1 and 3 (each within the scatter of the next); then compound 2.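

In this assay, isopropylsulfanyl on the carbonyl carbon does not hold what diethylamino gave: the exchange brings a number 34 percentage points lower from compound 2 to compound 3 (beyond the scatter) and removes the whole of the earlier gain. Set against the methyl of compound 1, the same group shows no change at the digits printed from compound 1 to compound 3 (within the scatter) and so leaves methyl and isopropylsulfanyl indistinguishable on this read-out, with diethylamino the only one of the three groups that stands apart. The earlier compounds showed that this position could move the read-out, while compound 3 shows that a change here need not do so, and nothing at hand explains the difference between diethylamino and isopropylsulfanyl.

The compounds shown leave open whether the higher number belongs to amines at this carbonyl carbon in general or to diethylamino alone, a question that dimethylamino, pyrrolidine or a simple ethoxy group in the same place would help to settle. From the compounds shown here alone, it is also open whether the same order of these groups would hold with a substituent other than the one carried by the shared core here.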